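The compounds below may be only part of what the source reports. "The series", "measured", "known", "first", "only" and "open" are said of these compounds alone.

Two compounds share one core and differ only in the aromatic ring attached to the carbonyl carbon of the ester. Compound 1 `COC(=O)/C(=C\c1ccc(OC(=O)c2c(OC)cccc2OC)cc1)Sc1ccnc2cc(Cl)ccc12` carries a 2,6-dimethoxyphenyl there, and in a functional assay on HL-60 cells (Homo sapiens) for cytotoxicity, read by MTT assay, with a stated time of 24 h (a lower number here means a stronger inhibitor, a higher number a weaker inhibitor), compound 1 gives 37200 nM. Compound 2 `COC(=O)/C(=C\c1ccc(OC(=O)c2cc(OC)cc(OC)c2OC)cc1)Sc1ccnc2cc(Cl)ccc12` carries a 2,3,5-trimethoxyphenyl instead, and in this assay compound 2 gives 10700 nM. That single change produced a 3.5-fold lower number from compound 1 to compound 2 (0.54 log units; beyond the scatter), so compound 2 holds the lower of the two numbers, and the gap to compound 1 is beyond the scatter.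

Compound 3 `COC(=O)/C(=C\c1ccc(OC(=O)c2cc(OC)c(OC)cc2OC)cc1)Sc1ccnc2cc(Cl)ccc12` is the next variation. Its difference from compound 2 is 2,4,5-trimethoxyphenyl in place of 2,3,5-trimethoxyphenyl on a carbonyl carbon. Here the same three methoxy groups stay on the ring; only their arrangement moves. Among the measured compounds shown here, the one measured step, from compound 1 to compound 2, changed the number of methoxy groups, so it speaks only loosely to a rearrangement of the same groups. For the measured compounds named here, with no closer precedent, the expected step of a 1.1-fold lower number from compound 2 to compound 3 (0.03 log units; within the scatter) in this assay is none beyond the scatter. Compound 3 is therefore estimated at 10000 nM, with a likely range from 3500 nM to 30000 nM.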

Compound 3, half-maximal inhibitory concentration: 6260 nM
Compound 3: the middle estimate sits 1.6-fold (0.20 log units) above what was measured, and the stated range covers the measured number.
By their numbers in this assay, from the lowest: compounds 3 and 2 (each within the scatter of the next); then compound 1.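

In this assay, moving the methoxy groups around the ring gives a 1.7-fold lower number from compound 2 to compound 3 (0.23 log units; within the scatter) and so does not separate the 2,4,5-trimethoxyphenyl from the 2,3,5-trimethoxyphenyl, which makes this the first sign that this position can tolerate at least one rearrangement of these groups without a clear shift in the number. The 2,4,5-trimethoxyphenyl in place of the 2,6-dimethoxyphenyl gives a 5.9-fold lower number from compound 1 to compound 3 (0.77 log units; beyond the scatter) and thus, like compound 2, stands clearly apart from compound 1, although this swap alters both the number of methoxy groups and their arrangement, so the two changes cannot be separated here. No measurement of any property of these groups accompanies the numbers, so nothing here explains these differences.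

Every group shown on this carbonyl carbon is a phenyl ring bearing methoxy groups, so it stays open what a plain phenyl, or a phenyl carrying hydroxy or amino groups instead, would do in this assay. From the compounds shown here alone, it also stays open whether the number would hold if an amide replaced the ester that links this ring to the shared core.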